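The source may report more compounds than this note shows. Statements on the series, on what has been measured and on what is new or still open speak of the compounds shown alone.

Working notes on the series.

The shared core carries a phenyl on the ring amine nitrogen, and the measured compounds differ only in what sits on that phenyl. Compound 2 `CC(C(=O)N1CCN(c2ccccc2)CC1)N1C(=O)CCC1=O` bears the unsubstituted phenyl, compound 1 `COc1cccc(N2CCN(C(=O)C(C)N3C(=O)CCC3=O)CC2)c1` a 3-methoxyphenyl and compound 3 `CC(C(=O)N1CCN(c2ccc(F)cc2)CC1)N1C(=O)CCC1=O` a 4-fluorophenyl. In a functional assay on the whole organism (strain Swiss) with Mus musculus as the target, in the maximal electroshock model, with a stated time of 0.5 h, at a dose of 100 mg/kg by the intraperitoneal route (a higher number here means a stronger effect of the compound at the dose given, a lower number a weaker effect), compound 2 gives 0%; compound 1 gives 0% and compound 3 gives 0%. Compound 2 therefore stands level with both companions, nearest to compound 1 and no further from compound 3, with nothing among the three rising beyond the scatter.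

Compound 4 `CC(C(=O)N1CCN(c2ccccc2C(F)(F)F)CC1)N1C(=O)CCC1=O` is the next member, and differs from compound 2 by trifluoromethyl in place of hydrogen on an aromatic carbon.

Among the measured compounds shown here, the steps that bear on this are the other changes on the same aromatic ring: no change at the digits printed from compound 1 to compound 2 (within the scatter), no change at the digits printed from compound 2 to compound 3 (within the scatter) and no change at the digits printed from compound 1 to compound 3 (within the scatter). Each of them left the read-out where it was. For the measured compounds named here, nothing in these numbers distinguishes one ring substituent from another, and no measured step shows the ring tolerating or rejecting a group at the place now in question, so the expectation for this assay is again no movement beyond the scatter, with a wide allowance for the untested substituent.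

Compound 4 is expected to give 5%, within a range of 0% to 30%, which corresponds to an estimated step of a number 5 percentage points higher from compound 2 to compound 4 (within the scatter).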

Compound 4, a percentage reported as activity, at one dose (the size of the read-out at that dose, not a potency): 25%
Compound 4: the middle estimate sits 20 percentage points below what was measured, and the stated range covers the measured number.
By their numbers in this assay, from the lowest: compounds 1, 2 and 3 (each within the scatter of the next); then compound 4.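

In this assay trifluoromethyl in place of hydrogen on an aromatic carbon, ortho to a large group, gives a number 25 percentage points higher from compound 2 to compound 4 (beyond the scatter) and is the only step shown that lies beyond the scatter. The earlier steps shown here, such as no change at the digits printed from compound 1 to compound 2 (within the scatter) and no change at the digits printed from compound 2 to compound 3 (within the scatter) on the same ring, gave no sign that a change there could register at all, whereas this change shows that the read-out of the shared core can respond to a substituent on the phenyl, though only modestly. Nothing available accounts for the rise seen with this group at this place.

The compounds shown leave open whether the step belongs to the place or to trifluoromethyl itself, since no other group stands ortho to a large group here, and a methyl, a chlorine, a nitrile or an amine at that place would separate the two. They also leave open whether trifluoromethyl elsewhere on the same phenyl would give a comparable step, or whether a larger step could be reached with a longer fluorinated chain.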